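The source may hold more compounds than are shown below. What is called first, only, known or untested is meant among the compounds shown, and "the series" means these compounds.

Measured compounds:
Compound 1 `CCOC(=O)c1cc(-c2csc(Nc3ccc(C)cc3)n2)on1` gives < 0.0167 h in an ADME assay on microsomes from liver (Homo sapiens) for metabolic stability, read by LC-MS, tested at 1 uM; a higher number here means that the compound lasts longer, a lower number that the compound disappears faster; this is a limit of the assay, not a number (the limit of < 0.0167 h in this assay, at which 1 of the 2 values shown sits).
Compound 2 `Cc1ccc(Nc2nc(-c3cc(C(=O)O)no3)cs2)cc1` gives 0.238 h in this assay.

Going by the values given here, compound 2 therefore stands as the only compound with a measured number; the other value is a limit. Among the compounds with values here, the single measured step, an at least 14-fold higher number from compound 1 to compound 2 (1.15 log units; beyond the scatter), took the ethyl ester to the free acid and was large. Compound 3 `Cc1ccc(Nc2nc(-c3cc(C(=O)Nc4ccccc4)no3)cs2)cc1` differs from compound 2 by anilino in place of hydroxy on a carbonyl carbon. Within the data shown here, this is a different kind of change from the measured one: the acid becomes an amide, not an ester, so the measured step offers only loose guidance, and no measured pair shows an amide. The expectation is a modest drop that stays within the scatter, a 1.6-fold lower number from compound 2 to compound 3 (0.20 log units; within the scatter). Compound 3 is estimated at 0.15 h, with a range from 0.04 h to 0.5 h.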

Compound 3, half-life: 0.585 h
Estimate against measurement, compound 3: 3.9-fold (0.59 log units) below, and the stated range ends below it.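

In this assay, anilino in place of hydroxy on the carbonyl carbon gives a 2.5-fold higher number from compound 2 to compound 3 (0.39 log units; beyond the scatter), which shows that the free acid is not the only form here that outlasts the ethyl ester. Compound 3, an amide, now lasts longest of the three, even though this change adds a whole six-membered aromatic ring. The step from the ethyl ester reads an at least 35-fold higher number from compound 1 to compound 3 (1.54 log units; beyond the scatter), and it rests on a value of compound 1 that is a limit of the assay, not a number: the limit of < 0.0167 h in this assay, at which 1 of the 3 values shown sits.

The compounds shown leave open whether the longer half-life comes from the amide link itself or from the added aromatic ring. A plain primary amide or a methylamino amide at this carbonyl carbon would help separate the two.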